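Trading a Dipropylamino Group for a Hydroxypiperidine Ring

The source may report more compounds than this note shows. Statements on the series, on what has been measured and on what is new or still open speak of the compounds shown alone.

Of the compounds shown here, three built on one shared core have been measured in a functional assay on CHO-K1 cells for antagonist activity at transient receptor potential cation channel subfamily V member 1 (Homo sapiens), read by FLIPR; on this read-out higher numbers stand for weaker inhibition and lower numbers for stronger inhibition. Compound 1 `CCCN(CCC)c1nc(C(F)(F)F)ccc1CNC(=O)C(C)c1ccc(NS(C)(=O)=O)c(F)c1` gives 14.7 nM. Compound 2 `C[C@H](C(=O)NCc1ccc(C(F)(F)F)nc1N1CC[C@@H](OCc2ccccc2)C1)c1ccc(NS(C)(=O)=O)c(F)c1` gives 50 nM, and compound 3 `C[C@H](C(=O)NCc1ccc(C(F)(F)F)nc1N1CCC(c2ccccc2)CC1)c1ccc(NS(C)(=O)=O)c(F)c1` gives 17.4 nM. Compound 1 holds the lowest of the three numbers, but its nearest neighbour, compound 3, sits within the usual scatter of it, so those two cannot be told apart; compound 2 lies beyond the scatter and is the weaker inhibitor of that pair.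

The unmeasured compound 4 `CC(C(=O)NCc1ccc(C(F)(F)F)nc1N1CCC(O)CC1)c1ccc(NS(C)(=O)=O)c(F)c1` differs from compound 1 in a single place: 4-hydroxypiperidin-1-yl in place of dipropylamino on an aromatic carbon. The leaving and entering groups match in heavy-atom count, yet the entering group brings a six-membered non-aromatic ring and a hydrogen-bond donor that the dipropylamino group does not have.

For the measured compounds named here, no pair of measured compounds shows this kind of change, so the expectation rests on compound 1 and the spread of the three numbers. A moderate rise in the number, a 4.1-fold higher number from compound 1 to compound 4 (0.61 log units; beyond the scatter), is expected, meaning somewhat weaker inhibition. Compound 4 is therefore estimated to give about 60 nM, with a likely range from 20 nM to 200 nM.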

Compound 4, half-maximal inhibitory concentration: "not active" (no number reported)
Compound 4 has no reported number here; the estimate stays without a comparison.
By their numbers in this assay, from the lowest: compounds 1 and 3 (each within the scatter of the next); then compound 2.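

In this assay, for the compounds shown here, compound 4 is reported as "not active", with no number, so no step from compound 1 to compound 4 can be read. No measured evidence bearing on this result is available. The compounds shown leave open how far swapping dipropylamino for 4-hydroxypiperidin-1-yl on its own shifts inhibition.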